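The compounds below may be only part of what the source reports. "The series", "measured", "known", "first", "only" and "open" are said of these compounds alone.

In an ADME assay on HepG2 2.2.15 cells (Homo sapiens) for cytotoxicity, read by MTT assay, with stated times of 48 h and 9 days; a lower number here means that less compound is tolerated, a higher number that more compound is tolerated:
Compound 1 `COc1ccc2c(=O)c(/C=C/C(=O)Nc3cccc(C)c3)coc2c1`: 554000 nM
Compound 2 `COc1ccc2c(=O)c(/C=C/C(=O)NCc3ccccc3F)coc2c1`: 146000 nM
Compound 3 `COc1ccc2c(=O)c(/C=C/C(=O)NCc3ccc(C)cc3)coc2c1`: 257000 nM
Compound 4 `COc1ccc2c(=O)c(/C=C/C(=O)NCc3ccc(F)cc3F)coc2c1`: not yet measured

Compound 3 finds its nearest neighbour on these numbers in a 1.8-fold higher number from compound 2 to compound 3 (0.25 log units; within the scatter), and its furthest in a 2.2-fold lower number from compound 1 to compound 3 (0.33 log units; beyond the scatter). Compound 4 differs from it by 2,4-difluorophenyl in place of 4-methylphenyl on a saturated chain carbon bound to an amide-type nitrogen. The closest guide is the step just cited between the two benzyl compounds, which stayed within the scatter. The modest 3.8-fold lower number from compound 1 to compound 2 (0.58 log units; beyond the scatter) replaced 3-methylphenyl, a group absent from this pair, and so bears less. In this assay, a slight fall at most is therefore expected, with nothing beyond the scatter. The expected change is a 1.5-fold lower number from compound 3 to compound 4 (0.18 log units; within the scatter). For compound 4 the estimated value is 170000 nM, with an expected range of 85000 nM to 340000 nM.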

Compound 4, half-maximal cytotoxic concentration: 79300 nM
For compound 4 the middle estimate is 2.1-fold (0.33 log units) above the measured one; measured number below the stated range.
By their numbers in this assay, from the lowest: compounds 4, 2 and 3 (each within the scatter of the next, the first and the last beyond it); then compound 1.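

In this assay the change to 2,4-difluorophenyl on a saturated chain carbon bound to an amide-type nitrogen brings a 3.2-fold lower number from compound 3 to compound 4 (0.51 log units; beyond the scatter) and so shows, as the earlier benzyl pair did not, that a change at this position can move the number beyond the scatter. The added fluoro alone gives a 1.8-fold lower number from compound 2 to compound 4 (0.27 log units; within the scatter) and stays within it, while a 7.0-fold lower number from compound 1 to compound 4 (0.84 log units; beyond the scatter) is the largest step among the four compounds. Nothing available explains these steps. The compounds shown leave open how a trifluoromethyl group or an amine on the benzyl ring would fare, and what a longer chain on the amide-type nitrogen would do.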